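The compounds below may be only part of what the source reports. "The series", "measured", "known", "first", "only" and "open" are said of these compounds alone.

Compound 1 `CCCCCCCCCCCC[C@@H](O)[C@H]1CC[C@H]([C@H](O)CCCCCCCCCCN(C)C(=O)c2ccnn2C)O1` is a long-chain compound with a saturated ring and two free hydroxyl groups, capped at the far end of its chain by a methyl-substituted amide of a methylpyrazole. In a functional assay on SF-539 cells (Homo sapiens) for inhibition, read by sulforhodamine B assay, with a stated time of 48 h (a higher number here means a weaker inhibitor of growth, a lower number a stronger inhibitor of growth), compound 1 gives 12000 nM, which places it second highest among the three measured compounds. Its nearest neighbour is compound 2 `CCCCCCCCCCCC[C@@H](O)[C@H]1CC[C@H]([C@H](O)CCCCCCCCCCNCc2ccnn2C)O1`, which gives 1580 nM, the step being a 7.6-fold lower number from compound 1 to compound 2 (0.88 log units; beyond the scatter). Compound 3 `CCCCCCCCCCCC[C@@H](O)[C@H]1CC[C@H]([C@H](O)CCCCCCCCCCC(=O)Nc2ccnn2C)O1`, in which the amide is turned around, gives 100000 nM; that step is an 8.3-fold higher number from compound 1 to compound 3 (0.92 log units; beyond the scatter).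

Compound 4 `CCCCCCCCCCCC[C@@H](O)[C@H]1CC[C@H]([C@H](O)CCCCCCCCCCOC(=O)c2ccnn2C)O1` is the unmeasured member of the set. It differs from compound 1 as follows: ((1-methyl-1H-pyrazol-5-yl)carbonyl)oxy in place of methyl((1-methyl-1H-pyrazol-5-yl)carbonyl)amino on a saturated chain carbon, ten or more bonds along the chain from an oxygen on a saturated carbon and a saturated ring carbon. For the measured compounds named here, no measured step swaps this group for an ester, so the expectation rests on the two steps from compound 1. Both capping changes moved the number well beyond the scatter, in opposite directions, so a change of modest size either way is plausible. Keeping the carbonyl but losing the nitrogen, compound 4 is expected to land near or somewhat above compound 1, at an estimated 18000 nM with a range of 4000 nM to 70000 nM, a step of a 1.5-fold higher number from compound 1 to compound 4 (0.18 log units; within the scatter).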

Compound 4, concentration for 50% growth inhibition: 100000 nM
The estimate for compound 4 lay 5.6-fold (0.74 log units) below the measured number; the whole stated range lies below it.
By their numbers in this assay, from the lowest: compound 2; then compound 1; then compounds 3 and 4 (each within the scatter of the next).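

Swapping the methylated amide nitrogen for the ester oxygen gives an 8.3-fold higher number from compound 1 to compound 4 (0.92 log units; beyond the scatter) in this assay and leaves the result level with the reversed amide, with no change at the digits printed from compound 3 to compound 4 (within the scatter) between those two caps. A carbonyl in the linker therefore does not set the number by itself, since compound 1 also carries one yet stands apart from compound 3 and compound 4. Compound 2, the only cap of the four without a carbonyl, gives the lowest number, and the ester cap shows a 63-fold higher number from compound 2 to compound 4 (1.80 log units; beyond the scatter) against it. Nothing given here explains why these caps differ.

Going by these compounds, it remains open whether the lower number of compound 2 depends on its amine nitrogen, which an ether linker at the same place would test. On these data alone, the effect of a methyl group on that amine, or of a carboxylic acid at the chain end, also remains unknown.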